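Notes on compound 3 and the proposed compound 4

This account rests on a few compounds, and the source may have more. Where it says the series, first, only, none or still open, it means among the compounds named here.

Measured so far in a functional assay on A549 cells (Homo sapiens) for cytotoxicity, read by MTT assay, with a stated time of 48 h; a higher number here means a weaker inhibitor, a lower number a stronger inhibitor:
- compound 1 `Cc1nnc(SCC(=O)c2ccc(Cl)cc2)n1N1C(=O)c2ccccc2C1=O` gives > 200000 nM, a limit of the assay
- compound 2 `CCCc1nnc(SCC(=O)c2ccc(Cl)cc2)n1N1C(=O)c2ccccc2C1=O` gives > 200000 nM, a limit of the assay
- compound 3 `COc1cc(-c2nnc(SCC(=O)c3ccc(Cl)cc3)n2N2C(=O)c3ccccc3C2=O)cc(OC)c1OC` gives 9030 nM

Compound 3 is the only one of the three with a number in this assay. Compound 1 and compound 2 both sit at the limit of > 200000 nM in this assay, at which 2 of the 3 values shown sit. The two steps that lead to compound 3 are large: an at least 22-fold lower number from compound 1 to compound 3 (1.34 log units; beyond the scatter) and an at least 22-fold lower number from compound 2 to compound 3 (1.34 log units; beyond the scatter). Between the two limits the step is a step that the two limits leave unreadable from compound 1 to compound 2.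

Compound 4 `COc1cc(-c2nnc(SCC(=O)c3ccc(F)cc3)n2N2C(=O)c3ccccc3C2=O)cc(OC)c1OC` differs from compound 3 in one place: fluoro in place of chloro on an aromatic carbon. Among the compounds with values here, none of the measured steps touches this place; all three measured compounds carry the chloro group, and the steps so far concern only the group on the shared core. Within the data shown here, there is thus no measured step to size this change against. The expectation for compound 4 in this assay is a 1.3-fold higher number from compound 3 to compound 4 (0.12 log units; within the scatter), a step within the scatter, with neither direction favoured. The estimate for compound 4 in this assay is 12000 nM, with a range from 4000 nM to 40000 nM.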

Compound 4, half-maximal inhibitory concentration: > 200000 nM
Compound 4 was reported as a limit; the forecaster's own chance of this, stated with the estimate: 10%; middle value at least 16-fold (1.22 log units) away from the limit.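

In this assay, within the data shown here, the place on the 4-chlorophenyl group, which no earlier step touched, proves able to decide the result: fluoro in place of chloro gives an at least 22-fold higher number from compound 3 to compound 4 (1.34 log units; beyond the scatter). Among these compounds, until now, the only readable steps concerned the group on the shared core, and they pointed to 3,4,5-trimethoxyphenyl alone; among the four compounds, however, a number appears only in compound 3, the one compound that carries both 3,4,5-trimethoxyphenyl and chloro. Compound 4 is reported only as a limit of the assay, and it joins the others there: the limit of > 200000 nM in this assay, at which 3 of the 4 values shown sit.

The true size of the step remains open, as does whether the drop is tied to fluoro or whether chloro is the unusual case, since only these two groups are shown at this place. Bromo, trifluoromethyl or a plain hydrogen on the same aromatic carbon, each paired with 3,4,5-trimethoxyphenyl, would show how narrowly the number in this assay depends on the chloro group.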